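Series notes: ethylsulfanyl replacing cyanomethyl on the shared core

The source may report more compounds than this note shows. Statements on the series, on what has been measured and on what is new or still open speak of the compounds shown alone.

Of the compounds shown here, three of the shared core have been measured in a functional assay on the whole organism with Rattus norvegicus as the target, with a stated time of 4 h, at a dose of 40 mg/kg by the intraperitoneal route; a higher number here means more inhibition at the dose given (going by the name of the read-out), a lower number less inhibition. Compound 1, `Cc1nc2c(COc3ccccc3)cccn2c1C`, gives 48% in this assay. Compound 2, `Cc1nc2c(CSc3ccccc3)cccn2c1C`, gives 29%. Compound 3, `Cc1nc2c(OCc3ccccc3)cccn2c1CCC#N`, gives 40%. On these numbers compound 3 sits together with compound 1, the gap between them within the usual scatter, while compound 2 stands apart from compound 3 by a gap beyond the scatter, with compound 2 the lower of the two.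

Compound 4, `CCSCc1c(C)nc2c(OCc3ccccc3)cccn12`, has not been measured. It differs from compound 3 in one place: ethylsulfanyl in place of cyanomethyl on a saturated chain carbon bound to an aromatic carbon. No step between measured compounds covers this change, so the expectation rests only on the three numbers shown. Compound 4 is expected to sit near compound 3, with a step of a number 4 percentage points lower from compound 3 to compound 4 (within the scatter) that is expected to lie within the scatter or a little below it. The estimate for compound 4 in this assay is 36%, with a range from 16% to 56%.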

Compound 4, a percentage reported as inhibition, in the whole organism at one dose (the size of the read-out at that dose, not a potency): 36%
The estimate for compound 4 equals the measured number at the digits printed; measured number inside the range.
By their numbers in this assay, from the lowest: compounds 2, 4, 3 and 1 (each within the scatter of the next, the first and the last beyond it).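

In this assay, among the compounds shown here, the first step at this position reads a number 4 percentage points lower from compound 3 to compound 4 (within the scatter) for ethylsulfanyl in place of cyanomethyl on a saturated chain carbon bound to an aromatic carbon, so the two compounds cannot be told apart at the dose given. In this pair, a nitrile on the chain is therefore not needed for a read-out within the scatter of compound 3, and a group holding sulfur, with the same count of heavy atoms, serves equally. The data offer no explanation for this result.

Still open, as far as these compounds go, is how much change this position accepts: an amine, a carboxylic acid or a longer chain such as propylsulfanyl in the same place would test that. A single pair also leaves open whether the same change reads the same way on another core.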